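The source may hold more compounds than are shown below. What is called first, only, known or untested is meant among the compounds shown, and "the series" means these compounds.

Notes on the series. Compound 1 `O=C(O)c1ccc(CCCN2C(=O)CC[C@@H]2CCC(O)Cc2ccccc2)s1` gives 690 nM in an assay on HEK293 cells for binding affinity to prostaglandin E2 receptor EP2 subtype (Rattus norvegicus); on this read-out lower numbers stand for stronger inhibition and higher numbers for weaker inhibition. Compound 2 `O=C(O)CCCCCCN1C(=O)CC[C@@H]1CC[C@@H](O)Cc1cccc(-c2ccccc2)c1` reaches only a limit of the assay there, > 3200 nM, so its true number is not known; this is the limit of > 3200 nM in this assay, at which 1 of the 2 values shown sits. Compound 3 `O=C(O)CCCCCCN1C(=O)CC[C@@H]1CC[C@@H](O)Cc1cccc(OC(F)(F)F)c1` has not been measured in this assay. It differs from compound 2 in one place: trifluoromethoxy in place of phenyl on an aromatic carbon. Among the measured compounds shown here, no measured pair shows this change, so the size of the step from compound 2 to compound 3 cannot be read from the numbers, and with compound 2 standing at a limit the starting point itself is open. The step from compound 2 to compound 3 is nonetheless expected to run toward lower numbers, an at least 1.6-fold lower number from compound 2 to compound 3 (0.20 log units; that floor lies within the scatter), with wide uncertainty. Compound 3 is expected to give 2000 nM, between 500 nM and 8000 nM, and a further limit reading would not be surprising.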

Compound 3, half-maximal inhibitory concentration: > 3200 nM
Compound 3: a limit, no number (the forecaster's own chance of this, stated with the estimate: 40%); at least 1.6-fold (0.20 log units) between middle value and limit.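

Compound 2 and compound 3 both stand at a limit in this assay, so no step can be read between them: the limit of > 3200 nM in this assay, at which 2 of the 3 values shown sit. The compounds shown leave open where the true values of compound 2 and compound 3 lie, and whether trifluoromethoxy in place of phenyl changes the read-out at all.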